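Cyano for Bromo on a Sulfonyl Aryl Ring

The source may report more compounds than this note shows. Statements on the series, on what has been measured and on what is new or still open speak of the compounds shown alone.

The series rests on a shared core carrying an arylsulfonyl group, and three of its members have been tested. Compound 1 `O=C1/C(=C/c2ccncc2)CN(S(=O)(=O)c2ccc(Br)cc2)C/C1=C\c1ccccc1F` gives 12600 nM in a functional assay on SMMC-7721 cells (Homo sapiens) for cytotoxicity, read by MTT assay, with a stated time of 24 h; a higher number here means a weaker inhibitor, a lower number a stronger inhibitor. Compound 2 `N#Cc1ccc(S(=O)(=O)N2C/C(=C\c3ccncc3)C(=O)/C(=C/c3ccccc3F)C2)cc1`, in this assay, gives 16200 nM. The two differ only in one place, (cyano in place of bromo on an aromatic carbon), and the step of a 1.3-fold higher number from compound 1 to compound 2 (0.11 log units; within the scatter) is within the scatter, so these two values cannot be ranked against each other. Compound 3 `O=C1/C(=C/c2cccnc2)CN(S(=O)(=O)c2ccc(Br)cc2)C/C1=C\c1ccccc1C(F)(F)F` carries a different core; how its core differs from that of compound 1 is not broken down here. In this assay compound 3 gives 5760 nM, the lowest of the three numbers and beyond the scatter from both others.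

Compound 4 `N#Cc1ccc(S(=O)(=O)N2C/C(=C\c3cccnc3)C(=O)/C(=C/c3ccccc3C(F)(F)F)C2)cc1` has not yet been measured. It stands to compound 3 as compound 2 stands to compound 1: the change is cyano in place of bromo on an aromatic carbon, the same kind of change seen once already among these compounds. Since that earlier step between compound 1 and compound 2 was small, the step from compound 3 to compound 4 is expected to be of similar size, a 1.3-fold higher number from compound 3 to compound 4 (0.11 log units; within the scatter), because a 1.3-fold higher number from compound 1 to compound 2 (0.11 log units; within the scatter) was within the scatter. On that basis compound 4 is estimated to give about 7500 nM in this assay, with a plausible range from 3500 nM to 16000 nM.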

Compound 4, half-maximal inhibitory concentration: 9650 nM
Beside the measured number, compound 4's estimate is 1.3-fold (0.11 log units) below it; low and high end bracket the measured number.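

In this assay, putting cyano in place of bromo on the core of compound 3 gives a 1.7-fold higher number from compound 3 to compound 4 (0.22 log units; within the scatter) and so leaves these two compounds unranked, as the same exchange did for compound 1 and compound 2. Set side by side, the two steps cannot be told apart: the same change on two cores in this assay, a 1.3-fold higher number (0.11 log units; within the scatter) from compound 1 to compound 2 and a 1.7-fold higher number (0.22 log units; within the scatter) from compound 3 to compound 4, 1.3-fold (0.11 log units) apart, within the scatter of two such steps. This shows that, on the two cores tested, the exchange of 4-bromophenyl for 4-cyanophenyl on the sulfonyl group produced no readable shift in this cytotoxicity read-out, and that the small step seen on the first core was also seen on the second; it does not show that the two groups are interchangeable on other cores or in other assays, and two pairs are too few to establish a rule for the series.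

The compounds shown leave open whether the same result would hold on a third core, since only bromo and cyano are compared at this place. They also leave open what an amine, a carboxylic acid or a longer chain at the same aromatic carbon would do to the cytotoxicity of either core.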